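One Aryl Swap Carried Over to a Second Core

The source may hold more compounds than are shown below. What is called first, only, known or untested is meant among the compounds shown, and "the series" means these compounds.

The measured compounds are:
compound 1 `Cc1ccc(S(=O)(=O)/C(=C/c2sccc2C)C(=O)c2ccc(Cl)cc2)cc1`, which in a functional assay on DU-145 cells (Homo sapiens) for inhibition, read by trypan blue exclusion, with a stated time of 96 h (on this read-out lower numbers stand for stronger inhibition of growth and higher numbers for weaker inhibition of growth), gives 10000 nM;
compound 2 `COc1ccccc1/C=C(\C(=O)c1ccc(Cl)cc1)S(=O)(=O)c1ccc(C)cc1`, which in this assay gives 1000 nM;
compound 3 `Cc1ccc(CS/C(=C/c2sccc2C)C(=O)c2ccc(Cl)cc2)cc1`, which in this assay gives 10000 nM.

Compound 1 and compound 2 differ in one place only: 2-methoxyphenyl in place of 3-methylthiophen-2-yl on a double-bonded chain carbon bound to a double-bonded chain carbon. That single change made a 10-fold lower number from compound 1 to compound 2 (1.00 log units; beyond the scatter).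

Compound 3 carries the same 3-methylthiophen-2-yl group as compound 1 but sits on a different core; the difference between the two cores is not broken down here. In this assay compound 3 and compound 1 show no change at the digits printed, and the two values lie within the usual scatter of each other.

Compound 4 `COc1ccccc1/C=C(/SCc1ccc(C)cc1)C(=O)c1ccc(Cl)cc1` has not yet been measured. It stands to compound 3 exactly as compound 2 stands to compound 1: 2-methoxyphenyl in place of 3-methylthiophen-2-yl on a double-bonded chain carbon bound to a double-bonded chain carbon. The place of the change is the same word for word, so it is the same change, now made on the core of compound 3 rather than on the core of compound 1.

From compound 3 to compound 4 a step of a 6.7-fold lower number from compound 3 to compound 4 (0.82 log units; beyond the scatter) is expected, set beside the earlier 10-fold lower number from compound 1 to compound 2 (1.00 log units; beyond the scatter). This expectation rests on that one earlier step alone. That step was seen only once and on a different core, so the range is kept wide. For compound 4 in this assay the estimate is 1500 nM, expected to fall between 400 nM and 6000 nM.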

Compound 4, concentration for 50% growth inhibition: 10000 nM
Beside the measured number, compound 4's estimate is 6.7-fold (0.82 log units) below it; measured number above the stated range.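

In this assay the swap did not carry over from one core to the other: putting 2-methoxyphenyl in place of 3-methylthiophen-2-yl on the core of compound 3 gave no change at the digits printed from compound 3 to compound 4 (within the scatter). Set beside the earlier result, the effect of this change in the series depends on the core that carries it: the same change on two cores in this assay, a 10-fold lower number (1.00 log units; beyond the scatter) from compound 1 to compound 2 and no change at the digits printed (within the scatter) from compound 3 to compound 4, 10-fold (1.00 log units) apart, beyond the scatter of two such steps. For the compounds shown here, this does not show which feature of the two cores makes the difference, nor does it give a general rule for other changes, since each core contributes a single pair and only this one swap is seen on both.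

The compounds shown leave open whether other groups in the same place, such as a plain phenyl, a pyridine ring, or a 2-methoxyphenyl group also carrying an amine or a carboxylic acid, would likewise give a lower number on the core of compound 1 alone. They also leave open whether any such group could lower the number on the core of compound 3, and whether a further core would follow the pattern of compound 1 and compound 2 or that of compound 3 and compound 4.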